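A few compounds are considered here, and "the series" means these few. Any claim that something is new, unique, unknown or untested is made for them only; others in the source may bear on it.

Working notes on the series. Among the compounds with values here, compound 2 `CC(C)C[C@H](N)c1cc(C(F)(F)F)ccc1N1CCN(C(=O)COc2ccc3ccccc3c2)CC1` stands as the higher of the two numbers measured so far in an assay on HEK293 cells for displacement of a labelled ligand from Melanocortin receptor 4 (Homo sapiens); on this read-out higher numbers stand for weaker inhibition and lower numbers for stronger inhibition: compound 2 gives 2000 nM, whereas compound 1 `COc1cc(Cl)ccc1C[C@@H](C)C(=O)N1CCN(c2ccc(C)cc2[C@@H](N)CC(C)C)CC1` gives 8.1 nM, a far lower number, with a gap well beyond the usual scatter. Within the data shown here, no single-change step between measured compounds is available, so the direction of the series must be read from these two values alone.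

Compound 3 `CCOc1cccc(CC(C)C(=O)N2CCN(c3ccc(C(F)(F)F)cc3[C@@H](N)CC(C)C)CC2)c1` is not yet measured. It differs from compound 2 in one place: 1-(3-ethoxybenzyl)ethyl in place of ((naphthalen-2-yl)oxy)methyl on a carbonyl carbon. The group that enters brings compound 3 closer to compound 1 on the carbonyl side of the shared core, and compound 1 gives 8.1 nM in this assay. On that basis a large step down is expected from compound 2 to compound 3, a 67-fold lower number from compound 2 to compound 3 (1.82 log units; beyond the scatter), clearly beyond the scatter. Compound 3 is therefore estimated at 30 nM in this assay, with a range from 8 nM to 150 nM.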

Compound 3, inhibition constant: 2200 nM
Compound 3: middle estimate off by 73-fold (1.87 log units), on the low side, outside the stated range (above it).
By their numbers in this assay, from the lowest: compound 1; then compounds 2 and 3 (each within the scatter of the next).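

In this assay, the exchange on a carbonyl carbon whose other neighbour is an amide-type nitrogen in a ring gives a 1.1-fold higher number from compound 2 to compound 3 (0.04 log units; within the scatter), so replacing ((naphthalen-2-yl)oxy)methyl with 1-(3-ethoxybenzyl)ethyl leaves the number within the scatter. Both groups have 12 heavy atoms and one hydrogen-bond acceptor, and going from two aromatic rings to one shows no separation here, while 1-(3-ethoxybenzyl)ethyl does not bring a low number with it in this setting. Nothing at hand bears on why these two groups read alike.

Compound 1, at 8.1 nM, differs from compound 3 in more than one place, so which difference goes with its value cannot be read from these compounds. Also open, going by these compounds, is whether an amine or a carboxylic acid on the group at this carbonyl carbon would separate from compound 2 and compound 3.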